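The compounds below may be only part of what the source reports. "The series", "measured", "known", "first", "only" and "open" are said of these compounds alone.

Working notes on the series. All four compounds share one core and differ only at two points: the ester alkyl and the halogen on the phenyl ring. Compound 1 `CCOC(=O)/C=C1/SC(N2N=C(c3cc4ccccc4o3)CC2c2ccc(F)cc2)=NC1=O`, compound 2 `CCOC(=O)/C=C1/SC(N2N=C(c3cc4ccccc4o3)CC2c2ccc(Cl)cc2)=NC1=O` and compound 3 `COC(=O)/C=C1/SC(N2N=C(c3cc4ccccc4o3)CC2c2ccc(F)cc2)=NC1=O` have been measured; compound 4 `COC(=O)/C=C1/SC(N2N=C(c3cc4ccccc4o3)CC2c2ccc(Cl)cc2)=NC1=O` has not.

In a functional assay on A549 cells (Homo sapiens) for antiproliferative activity, read by MTT assay, with a stated time of 96 h (a lower number here means a stronger inhibitor, a higher number a weaker inhibitor), compound 1 gives 0.93 ug/mL. In this assay compound 2 returns only a limit of the assay, > 5 ug/mL. In this assay compound 3 gives 0.808 ug/mL, the lowest of the two numbers shown, with compound 1 nearest; the step of a 1.2-fold lower number from compound 1 to compound 3 (0.06 log units; within the scatter) does not separate the two.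

Compound 4 differs from compound 3 by chloro in place of fluoro on an aromatic carbon; cut one bond further out, this reads 4-fluorophenyl to 4-chlorophenyl. The same exchange has been seen once in the series, as an at least 5.3-fold higher number from compound 1 to compound 2 (0.73 log units; beyond the scatter), which runs into (the limit of > 5 ug/mL in this assay, at which 1 of the 3 values shown sits). Given an at least 5.3-fold higher number from compound 1 to compound 2 (0.73 log units; beyond the scatter), a step of at least that size in the same direction is expected when the chloro analog is taken from the methyl ester compound 3, so compound 4 is expected to reach the limit as well. Compound 4 is therefore estimated at 6 ug/mL, with a range from 2.5 ug/mL to 15 ug/mL. The step expected is a 7.4-fold higher number from compound 3 to compound 4 (0.87 log units; beyond the scatter).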

Compound 4, half-maximal inhibitory concentration: 1.08 ug/mL
For compound 4 the middle estimate is 5.6-fold (0.74 log units) above the measured one; measured number below the stated range.
By their numbers in this assay, from the lowest: compounds 3, 1 and 4 (each within the scatter of the next). At a limit, above all of these: compound 2.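

In this assay, the step from 4-fluorophenyl to 4-chlorophenyl on the methyl ester is a 1.3-fold higher number from compound 3 to compound 4 (0.13 log units; within the scatter), so on this ester the fluoro and chloro analogs are not separated. The loss seen with the ethyl ester therefore does not carry over to the methyl ester, and the same exchange at this position reads differently on the two esters: the same change on two cores in this assay, an at least 5.3-fold higher number (0.73 log units; beyond the scatter) from compound 1 to compound 2 and a 1.3-fold higher number (0.13 log units; within the scatter) from compound 3 to compound 4, at least 4.0-fold (0.60 log units) apart, beyond the scatter of two such steps

The ester change, silent with the 4-fluorophenyl group, becomes visible with the 4-chlorophenyl group as an at least 4.6-fold lower number from compound 2 to compound 4 (0.66 log units; beyond the scatter), so the halogen and the ester alkyl cannot be read independently in this series: the same change on two cores in this assay, a 1.2-fold lower number (0.06 log units; within the scatter) from compound 1 to compound 3 and an at least 4.6-fold lower number (0.66 log units; beyond the scatter) from compound 2 to compound 4, at least 4.0-fold (0.60 log units) apart, beyond the scatter of two such steps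

As far as these compounds go, compound 2 returns only a limit of the assay, > 5 ug/mL, so the full size of the two steps that involve it stays open. Also open, from the compounds shown here alone, is whether this dependence on the ester persists with a bromo or methoxy group on the phenyl ring, or with a propyl ester or a carboxylic acid in place of the methyl ester.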